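Ring-Nitrogen Substituents in a Small T-type Channel Series

This account rests on a few compounds, and the source may have more. Where it says the series, first, only, none or still open, it means among the compounds named here.

Compound 1 `CCCc1nc(-c2ccccc2)c(CNCCCN2CCN(c3cccc(F)c3)CC2)o1` gives 68.9% in an assay on HEK293 cells for inhibition of Voltage-dependent T-type calcium channel subunit alpha-1G (Homo sapiens), read by fluorescence, tested at 10 uM; a lower number here means less inhibition, a higher number more inhibition at the concentration tested (going by the name of the read-out).
Compound 2 `CCCc1nc(-c2ccccc2)c(CNCCCN2CCN(c3ccc(OC)cc3)CC2)o1` gives 42.1% in this assay.
Compound 3 `CCCc1nc(-c2ccccc2)c(CNCCCN2CCN(c3ccccc3Cl)CC2)o1` gives 64.7% in this assay.

Compound 3 stands second highest of the three numbers: the step of a number 4.2 percentage points lower from compound 1 to compound 3 (within the scatter) lies within the scatter, while a number 22.6 percentage points higher from compound 2 to compound 3 (beyond the scatter) lies beyond it. Compound 4 `CCCc1nc(-c2ccccc2)c(CNCCCN2CCN(c3cccc(C)c3C)CC2)o1` differs from compound 3 by 2,3-dimethylphenyl in place of 2-chlorophenyl on an amine nitrogen in a ring. Within the data shown here, the steps that bear on this position are a number 26.8 percentage points lower from compound 1 to compound 2 (beyond the scatter) and a number 22.6 percentage points higher from compound 2 to compound 3 (beyond the scatter), both modest, and a number 4.2 percentage points lower from compound 1 to compound 3 (within the scatter), which was small. Among the measured compounds shown here, no measured compound carries a 2,3-dimethylphenyl group, so for compound 4 in this assay a step of a number 4.7 percentage points lower from compound 3 to compound 4 (within the scatter) is expected, not beyond the scatter. Compound 4 is therefore estimated at 60%, with a range from 40% to 78%.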

Compound 4, a percentage reported as inhibition, at one concentration (the size of the read-out at that concentration, not a potency): 55.2%
Compound 4: middle estimate off by 4.8 percentage points, on the high side; measured number inside the range.
By their numbers in this assay, from the lowest: compound 2; then compounds 4, 3 and 1 (each within the scatter of the next, the first and the last beyond it).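

With an all-carbon 2,3-dimethylphenyl group on the ring nitrogen, this assay gives a number 9.5 percentage points lower from compound 3 to compound 4 (within the scatter), so this change from 2-chlorophenyl cannot be read as a real loss. Compound 4 nevertheless separates from both other compounds, with a number 13.1 percentage points higher from compound 2 to compound 4 (beyond the scatter) and a number 13.7 percentage points lower from compound 1 to compound 4 (beyond the scatter), which places it in an intermediate position among these aryl groups. Nothing available explains these differences.

The compounds shown leave open how an unsubstituted phenyl group, a single methyl group or a carboxylic acid on this ring would read. They also leave open whether the same order holds with a longer chain in place of the propyl group.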